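A furan in place of a bromophenyl, repeated

A few compounds are considered here, and "the series" means these few. Any claim that something is new, unique, unknown or untested is made for them only; others in the source may bear on it.

Of the compounds shown here, three have so far been tested in a functional assay on PC-3 cells (Homo sapiens) for cytotoxicity, read by sulforhodamine B assay, with a stated time of 48 h; a lower number here means a stronger inhibitor, a higher number a weaker inhibitor. Compound 1 `CC(=O)N1N=C(c2cccc3ccccc23)CC1c1cccc(Br)c1` gives 12000 nM in this assay. Compound 2 `CC(=O)N1N=C(c2cccc3ccccc23)CC1c1ccco1` gives 18000 nM in this assay. The change from compound 1 to compound 2 is furan-2-yl in place of 3-bromophenyl on a saturated ring carbon, and a 1.5-fold higher number from compound 1 to compound 2 (0.18 log units; within the scatter). Compound 3 `O=CCN1N=C(c2ccc3ccccc3c2)CC1c1cccc(Br)c1` is built from the same atoms as compound 1, joined differently; the difference between the two cores is not broken down here. In this assay compound 3 gives 10900 nM, a number that lies within the scatter of both compound 1 and compound 2.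

Compound 4 `O=CCN1N=C(c2ccc3ccccc3c2)CC1c1ccco1` has not yet been measured in this assay. It differs from compound 3 by furan-2-yl in place of 3-bromophenyl on a saturated ring carbon. Going by the values given here, this is the same kind of change as the one from compound 1 to compound 2: in both cases the new group sits on a saturated ring carbon of a five-membered non-aromatic ring with 2 nitrogen, next to the ring nitrogen, but in compound 3 the neighbouring ring atom bears a formylmethyl group, whereas in compound 1 it bears an acetyl group. Because a 1.5-fold higher number from compound 1 to compound 2 (0.18 log units; within the scatter) stayed within the scatter, a step of similar size is expected here, a 1.5-fold higher number from compound 3 to compound 4 (0.17 log units; within the scatter). Compound 4 is therefore estimated at 16000 nM in this assay, with a likely range from 8000 nM to 35000 nM.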

Compound 4, half-maximal inhibitory concentration: 23000 nM
Compound 4: middle estimate off by 1.4-fold (0.16 log units), on the low side; low and high end bracket the measured number.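

Replacing 3-bromophenyl with furan-2-yl on the saturated ring carbon gives a 2.1-fold higher number from compound 3 to compound 4 (0.32 log units; beyond the scatter) in this assay. Set beside the same replacement on the core of compound 1, the step carries over to the core of compound 3 with no size difference that can be told apart from ordinary assay scatter: the same change on two cores in this assay, a 1.5-fold higher number (0.18 log units; within the scatter) from compound 1 to compound 2 and a 2.1-fold higher number (0.32 log units; beyond the scatter) from compound 3 to compound 4, 1.4-fold (0.15 log units) apart, within the scatter of two such steps This agreement rests on just two pairs of compounds, and only the step on the core of compound 3 lies beyond the scatter, and then only modestly, so the data show that the replacement behaved alike on these two cores, but not that it would do so on any other core, nor why the numbers take the values they do.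

Going by these compounds, only 3-bromophenyl and furan-2-yl appear at this saturated ring carbon, so it remains open how a group such as an amine, a carboxylic acid or a longer carbon chain would behave there. The ring atom that bears acetyl or formylmethyl is also explored by these two groups alone, which leaves open whether the replacement would carry over with a longer chain or an amine at that place.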